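Replacing pyridin-4-yl with 2,4-difluorophenyl: an expected gain

A few compounds are considered here, and "the series" means these few. Any claim that something is new, unique, unknown or untested is made for them only; others in the source may bear on it.

Three compounds have been measured in a functional assay on CHO cells with adenosine receptor A1 (Homo sapiens) as the target, read by cAMP accumulation and immunoassay, with a stated time of 6 min, tested at 10 uM; a higher number here means a weaker effect of the compound at the concentration tested, a lower number a stronger effect:
Compound 1 `Nc1scc(CN2CCN(c3ccc(Cl)cc3Cl)CC2)c1C(=O)c1ccc(Cl)cc1` gives -74%.
Compound 2 `Nc1scc(CN2CCN(c3ccc(Cl)c(C(F)(F)F)c3)CC2)c1C(=O)c1ccc(Cl)cc1` gives -60%.
Compound 3 `Nc1scc(CN2CCN(c3ccncc3)CC2)c1C(=O)c1ccc(Cl)cc1` gives -15%.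

Compound 3 stands highest of the three, which here means the weakest effect at the tested concentration. Its nearest neighbour is compound 2, and that gap, a number 45 percentage points higher from compound 2 to compound 3 (beyond the scatter), lies beyond the scatter; so does the larger gap to compound 1, a number 59 percentage points higher from compound 1 to compound 3 (beyond the scatter). In both steps the compound carrying pyridin-4-yl on the ring nitrogen gives the higher number.

The next compound, compound 4 `Nc1scc(CN2CCN(c3ccc(F)cc3F)CC2)c1C(=O)c1ccc(Cl)cc1`, differs from compound 3 in one place: 2,4-difluorophenyl in place of pyridin-4-yl on an amine nitrogen in a ring. This change returns to the kind of arrangement seen in compound 1 and compound 2, where a six-membered ring of carbon only with two substituents sits on the same ring nitrogen. For the measured compounds named here, the steps that bear on it are a number 59 percentage points higher from compound 1 to compound 3 (beyond the scatter) and a number 45 percentage points higher from compound 2 to compound 3 (beyond the scatter), both large and both running the opposite way. Compound 4 is therefore expected to show a large step downward, estimated as a number 45 percentage points lower from compound 3 to compound 4 (beyond the scatter). Going by the values given here, no measured pair shows how fluorine compares with chlorine in this spot, so the range is kept wide. The estimate for compound 4 is -60%, with a range from -80% to -30%.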

Compound 4, a percentage reported as activity, at one concentration (the size of the read-out at that concentration, not a potency): -82%
Compound 4: middle estimate off by 22 percentage points, on the high side; the measured number lies below the stated range.
By their numbers in this assay, from the lowest: compounds 4 and 1 (each within the scatter of the next); then compound 2; then compound 3.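

In this assay, for the compounds shown here, the first comparison of fluorine with chlorine in this spot gives a number 8 percentage points lower from compound 1 to compound 4 (within the scatter) and so does not separate 2,4-difluorophenyl from 2,4-dichlorophenyl, which means the swap from chlorine to fluorine costs nothing that this read-out can detect. The step of a number 22 percentage points lower from compound 2 to compound 4 (beyond the scatter) is modest but real, so the choice among carbon-only rings on this ring nitrogen still matters, while a number 67 percentage points lower from compound 3 to compound 4 (beyond the scatter) confirms with a third carbon-only ring the large difference from pyridin-4-yl that compound 1 and compound 2 had already shown. No measurement here explains why these groups differ.

With only disubstituted carbon-only rings on the ring nitrogen, the compounds shown leave open how plain phenyl, or a phenyl ring with a single fluorine, would compare with 2,4-difluorophenyl. Going by these compounds, it also remains open whether a methoxy group on the ring would fit this position as well as the halogens do, and whether pyridin-4-yl falls short in the same way against a pyridine ring bearing fluorine.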